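A few compounds are considered here, and "the series" means these few. Any claim that something is new, unique, unknown or untested is made for them only; others in the source may bear on it.

Compound 1, with the structure `CNC(=O)c1cc(C(=O)NC2CC2)cn(Cc2cccc3cc[nH]c23)c1=O`, and compound 2, with the structure `CNC(=O)c1cc(C(=O)NCCOC)cn(Cc2ccccc2)c1=O`, share one core and differ in the groups attached to it. In a physicochemical assay for lipophilicity, at pH 7.4 (on this read-out lower numbers stand for lower lipophilicity and higher numbers for higher lipophilicity), compound 1 gives 3.7, the higher of the two numbers, while compound 2 gives 2.7, a gap beyond the usual scatter. Compound 3, with the structure `CNC(=O)c1cc(C(=O)NC2CC2)cn(Cc2cccc3c2CCN3)c1=O`, has not yet been measured. It differs from compound 1 in a single place: 2,3-dihydro-1H-indol-4-yl in place of 1H-indol-7-yl on a saturated chain carbon bound to an aromatic nitrogen. The group that leaves carries a five-membered aromatic ring; the group that enters carries a five-membered non-aromatic ring and adds a hydrogen-bond acceptor, with the donor kept. Going by the values given here, no pair of measured compounds shows this exact change, so its effect can only be expected, not read off. The step of a number 0.30 log units lower from compound 1 to compound 3 (within the scatter) is expected to be small and downward, near the edge of the scatter. Compound 3 is therefore estimated at 3.4, within a range from 2.9 to 3.9.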

Compound 3, distribution coefficient: 2.1
Beside the measured number, compound 3's estimate is 1.30 log units above it; the measured number lies below the stated range.
By their numbers in this assay, from the lowest: compound 3; then compound 2; then compound 1.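

In this assay the swap of 1H-indol-7-yl for 2,3-dihydro-1H-indol-4-yl, on a saturated chain carbon bound to an aromatic nitrogen, produces a large step (a number 1.60 log units lower from compound 1 to compound 3 (beyond the scatter)). This shows that the read-out at this place responds strongly to the choice between two groups of equal size, with the same heavy atoms and the same hydrogen-bond donor count. Nothing measured here explains why the step is so large.

Going by these compounds, two things change together in this swap, the five-membered ring goes from aromatic to non-aromatic and the point of attachment moves, so their shares of the step remain open. 1H-indol-4-yl or 2,3-dihydro-1H-indol-7-yl at the same place would separate the two.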